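Extending the side chain of compound 2: cell tolerance

The source may hold more compounds than are shown below. What is called first, only, known or untested is meant among the compounds shown, and "the series" means these compounds.

Compound 1 (`CCCC(=O)OCSc1ccc(OC)cc1C(=O)NCCC(N)=O`): > 100 uM
Compound 2 (`CCCC(=O)OCSc1ccccc1C(=O)NCC(N)=O`): > 100 uM

In an ADME assay on CEM-SS cells (Homo sapiens) for cytotoxicity, read by XTT assay, with a stated time of 6 days (a lower number here means that less compound is tolerated, a higher number that more compound is tolerated), compound 2 gives > 100 uM as a limit of the assay, not a number. The data hold only the limit of > 100 uM in this assay, at which 2 of the 2 values shown sit, and so rank neither compound. Compound 3 (`CCCC(=O)OCSc1ccccc1C(=O)NCCCCNC(C)=O`) departs from compound 2 through the change 3-acetamidopropyl in place of carbamoyl on a saturated chain carbon bound to an amide-type nitrogen and has not yet been measured. For the measured compounds named here, no measured step exists to size this change, so in this assay no shift beyond the usual scatter is expected in either direction. The expected change is a number no higher from compound 2 to compound 3 (the limit leaves the size open) and may again read as a limit. For compound 3 the estimated value is 100 uM with an expected range from 40 uM to 200 uM in this measurement.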

Compound 3, half-maximal toxic concentration: 17.4 uM
The estimate for compound 3 lay 5.7-fold (0.76 log units) above the measured number, outside the stated range (below it).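

In this assay, for the compounds shown here, the change to 3-acetamidopropyl on a saturated chain carbon bound to an amide-type nitrogen gives an at least 5.7-fold lower number from compound 2 to compound 3 (0.75 log units; beyond the scatter) and so yields the first reading here that is a number and not a limit. This shows that the assay reading responds to a change at this place. The size of the step remains a bound, since compound 2 gives only a limit: the limit of > 100 uM in this assay, at which 2 of the 3 values shown sit.

The compounds shown leave open whether the longer chain or its terminal acetamide accounts for the step. A plain butyl chain or a 3-aminopropyl group at this place would separate the two.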